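Para-substituent swap at the aryl on the shared core

This account rests on a few compounds, and the source may have more. Where it says the series, first, only, none or still open, it means among the compounds named here.

Measured compounds in a functional assay on THP-1 cells (Homo sapiens) for inhibition, with a stated time of 48 h, tested at 50 uM; a lower number here means less inhibition of growth, a higher number more inhibition of growth at the concentration tested:
compound 1 `COc1ccccc1/C=C/[C@@](C)(/C=C/c1ccc(O)cc1)CCC=C(C)C`: 62%
compound 2 `COc1ccc(/C=C/[C@@](C)(/C=C/c2ccc(O)cc2)CCC=C(C)C)cc1`: 52%
compound 3 `CC(C)=CCC[C@](C)(/C=C/c1ccc(O)cc1)/C=C/c1ccc(F)cc1`: 60%

Compound 3 stands second highest of the three numbers in this assay. Its nearest neighbour is compound 1, a number 2 percentage points lower from compound 1 to compound 3 (within the scatter); its furthest is compound 2, a number 8 percentage points higher from compound 2 to compound 3 (within the scatter). All three values therefore lie within the usual scatter of one another, and no order among compounds 1, 2 and 3 can be read from them.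

Compound 4 `CC(C)=CCC[C@@](C)(/C=C/c1ccc(N)cc1)/C=C/c1ccc(O)cc1` differs from compound 3 in one place: amino in place of fluoro on an aromatic carbon. Within the data shown here, the only measured step at the same aromatic carbon is the one from compound 2 to compound 3, a number 8 percentage points higher from compound 2 to compound 3 (within the scatter), which stayed within the scatter. The change from compound 1 to compound 3, a number 2 percentage points lower from compound 1 to compound 3 (within the scatter), also left the number essentially unchanged. Each change at this aryl so far has moved the number by less than the scatter, so for the swap to amino no step beyond the scatter is expected in this assay, in either direction.

Compound 4 is expected to give 58% in this assay, within a range from 44% to 72%; the expected step is a number 2 percentage points lower from compound 3 to compound 4 (within the scatter).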

Compound 4, percent growth inhibition at one concentration: 51%
Beside the measured number, compound 4's estimate is 7 percentage points above it, within the range that was stated.
By their numbers in this assay, from the lowest: compounds 4, 2, 3 and 1 (each within the scatter of the next, the first and the last beyond it).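

In this assay, the swap to amino at this aromatic carbon gives a number 9 percentage points lower from compound 3 to compound 4 (within the scatter) and, against methoxy, a number 1 percentage points lower from compound 2 to compound 4 (within the scatter), so a group with a hydrogen-bond donor, which fluoro lacks, still gives no step beyond the scatter at this carbon. The series now also holds its first step beyond the scatter on this aryl, a number 11 percentage points lower from compound 1 to compound 4 (beyond the scatter), a modest one, but it replaces 2-methoxyphenyl with 4-aminophenyl, so the change of group and the change of its place on the ring cannot be separated. Nothing available bears on why the number moves across this step.

Still open, on these data alone, is whether a larger or charged group on the same aromatic carbon, such as a carboxylic acid or an acetamide, would give a step beyond the scatter from compound 4 in this assay. As far as these compounds go, since the read-out is percent growth inhibition at one concentration, how these compounds compare across a range of concentrations also remains open.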